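Thiophene for furan at the acyl group of compound 3

The compounds below may be only part of what the source reports. "The series", "measured", "known", "first", "only" and "open" are said of these compounds alone.

The series keeps the shared core and varies only the acyl group on the thiourea nitrogen. In an ADME assay on Huh-7 cells (Homo sapiens) for cytotoxicity (on this read-out lower numbers stand for higher toxicity in this test and higher numbers for lower toxicity in this test), compound 1 `O=C(NC(=S)N1CCc2c(OCCCCCOc3ccc(Cl)cc3)cccc21)c1ccc(F)cc1` gives 31100 nM. Compound 2 `COc1ccc(C(=O)NC(=S)N2CCc3c(OCCCCCOc4ccc(Cl)cc4)cccc32)cc1` gives 34400 nM in this assay, and compound 3 `O=C(NC(=S)N1CCc2c(OCCCCCOc3ccc(Cl)cc3)cccc21)c1ccoc1` gives 20100 nM. The three numbers sit within the usual scatter of one another: a 1.1-fold higher number from compound 1 to compound 2 (0.04 log units; within the scatter), a 1.5-fold lower number from compound 1 to compound 3 (0.19 log units; within the scatter) and a 1.7-fold lower number from compound 2 to compound 3 (0.23 log units; within the scatter). Compound 3 thus stands at no distance from compound 1 or compound 2 that this assay can resolve.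

Compound 4 `O=C(NC(=S)N1CCc2c(OCCCCCOc3ccc(Cl)cc3)cccc21)c1cccs1` differs from compound 3 in one place: thiophen-2-yl in place of furan-3-yl on a carbonyl carbon. Among the measured compounds shown here, no measured step exchanges one five-membered ring for another; the steps that bear on the change are those at the same carbonyl carbon, a 1.5-fold lower number from compound 1 to compound 3 (0.19 log units; within the scatter) and a 1.7-fold lower number from compound 2 to compound 3 (0.23 log units; within the scatter), both within the scatter, as is the change on the ring of compound 1 in a 1.1-fold higher number from compound 1 to compound 2 (0.04 log units; within the scatter). Three acyl groups of differing make-up gave numbers that cannot be told apart, so for compound 4 a step in this assay is expected of a 1.2-fold higher number from compound 3 to compound 4 (0.09 log units; within the scatter), no further than the scatter, in either direction. Compound 4 is therefore estimated at 25000 nM, with a range from 12000 nM to 50000 nM.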

Compound 4, half-maximal cytotoxic concentration: 10700 nM
Estimate against measurement, compound 4: 2.3-fold (0.37 log units) above; the measured number lies below the stated range.
By their numbers in this assay, from the lowest: compounds 4, 3, 1 and 2 (each within the scatter of the next, the first and the last beyond it).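

Among the compounds shown here, at this carbonyl carbon, this assay now separates acyl groups for the first time: thiophen-2-yl in place of 4-methoxyphenyl gives a 3.2-fold lower number from compound 2 to compound 4 (0.51 log units; beyond the scatter), and thiophen-2-yl in place of 4-fluorophenyl gives a 2.9-fold lower number from compound 1 to compound 4 (0.46 log units; beyond the scatter), both modest steps beyond the scatter. The exchange of one five-membered ring for another, however, gives a 1.9-fold lower number from compound 3 to compound 4 (0.27 log units; within the scatter), within the scatter, so thiophen-2-yl and furan-3-yl cannot be told apart here, and any reading that five-membered rings give lower numbers than substituted phenyl groups rests on compound 4 alone, with compound 3 going against it by staying within the scatter of both phenyl compounds. Nothing available on these compounds accounts for the lower number of compound 4.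

The compounds shown leave open whether the separation of compound 4 from the phenyl compounds follows the sulfur atom or the point of attachment on the ring, a question that a thiophen-3-yl or furan-2-yl acyl group would address. Also open, on these data alone, is how far the number moves with an aliphatic amine or a carboxylic acid on the acyl ring.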